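This account rests on a few compounds, and the source may have more. Where it says the series, first, only, none or still open, it means among the compounds named here.

Measured in a functional assay on HeLa cells (Homo sapiens) for cytotoxicity, read by WST assay, with a stated time of 48 h; on this read-out higher numbers stand for weaker inhibition and lower numbers for stronger inhibition:
Compound 1 `COC[C@H](C)[C@H](C)C(c1ccc(O)c(OC)c1)c1ccc(O)c(OC)c1` gives 72000 nM.
Compound 2 `COc1cc(C(c2ccc(O)c(OC)c2)[C@@H](C)[C@@H](C)CO)ccc1O` gives only a limit of the assay, > 100000 nM.
Compound 3 `COC[C@H](C)[C@@H](C)C(c1ccc(O)c(OC)c1)c1ccc(O)c(OC)c1` gives 77000 nM.

Compound 2 thus stands apart from the other two in that its value is a limit and not a number, as shown by the limit of > 100000 nM in this assay, at which 1 of the 3 values shown sits. Compound 1 and compound 3 differ only in configuration as drawn (the fact that compounds 1 and 3 differ only in the configuration as drawn), and the step of a 1.1-fold higher number from compound 1 to compound 3 (0.03 log units; within the scatter) is within the scatter. Putting hydrogen in place of methyl on the side-chain oxygen gave an at least 1.3-fold higher number from compound 1 to compound 2 (0.14 log units; that floor lies within the scatter), and the related change back gave an at least 1.2-fold lower number from compound 2 to compound 3 (0.11 log units; that floor lies within the scatter); both floors lie within the scatter.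

Compound 4 `COc1cc(C(c2ccc(O)c(OC)c2)[C@H](CF)C(C)C)ccc1O` is still to be measured in this assay. It differs from compound 2 by 1-(fluoromethyl)-2-methylpropyl in place of 2-(hydroxymethyl)-1-methylpropyl on a saturated chain carbon bound to two aromatic carbons. The counted difference shows that the side chain loses its hydrogen-bond donor and acceptor. The measured steps that bear on this change were all at or within the scatter, so no step beyond the scatter is expected in this assay. For compound 4 the expected step is an at least 1.1-fold lower number from compound 2 to compound 4 (0.04 log units; that floor lies within the scatter). Compound 4 is therefore estimated at 90000 nM, between 40000 nM and 200000 nM.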

Compound 4, half-maximal inhibitory concentration: 19000 nM
Compound 4: middle estimate off by 4.7-fold (0.68 log units), on the high side; measured number below the stated range.
By their numbers in this assay, from the lowest: compound 4; then compounds 1 and 3 (each within the scatter of the next). At a limit, above all of these: compound 2.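

Among the compounds shown here, at this place, on a saturated chain carbon bound to two aromatic carbons, the earlier steps showed nothing beyond the scatter in this assay, whereas the 1-(fluoromethyl)-2-methylpropyl chain gives a 4.1-fold lower number from compound 3 to compound 4 (0.61 log units; beyond the scatter) and a 3.8-fold lower number from compound 1 to compound 4 (0.58 log units; beyond the scatter). Both steps lie beyond the scatter and are similar in size, although they start from different compounds, so the drop does not depend on which of these two starting points is taken: the fact that compounds 1 and 3 differ only in the configuration as drawn Measured from the limit, the step reads an at least 5.2-fold lower number from compound 2 to compound 4 (0.72 log units; beyond the scatter), which is only a floor and not a full size: the limit of > 100000 nM in this assay, at which 1 of the 4 values shown sits.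

The change swaps oxygen for fluorine and also moves the branching of the chain, and the compounds shown do not separate these two changes. As far as these compounds go, whether an amine or a longer chain at this place would lower the number further stays open.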